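This account rests on a few compounds, and the source may have more. Where it says the series, first, only, none or still open, it means among the compounds named here.

Measured compounds:
- compound 1 `O=C(Nc1ccc(-c2ccccc2)cn1)c1ccccc1` gives 69 nM
- compound 2 `Cc1ccc(NC(=O)c2ccccc2)nc1` gives 6400 nM

Both numbers come from an assay on isolated protein (Aquatica lateralis) for inhibition of Luciferin 4-monooxygenase (Luciola lateralis), read by a luciferase reporter; on this read-out lower numbers stand for stronger inhibition and higher numbers for weaker inhibition. Among the measured compounds shown here, compound 1 stands lowest of the two; its nearest neighbour, compound 2, shows a 93-fold higher number from compound 1 to compound 2 (1.97 log units; beyond the scatter), which is the only step so far.

Compound 3 `O=C(Nc1ccc(-c2ccccc2)cn1)C1CCCCC1` has not been measured yet. It differs from compound 1 by cyclohexyl in place of phenyl on a carbonyl carbon. For the measured compounds named here, the one measured step, from compound 1 to compound 2, concerns a change on an aromatic carbon of the shared core, not on the carbonyl carbon, so it does not bear on this change directly; it only shows that a single swap of a group can move this assay a long way. Going by the values given here, no measured pair tells what exchanging an aromatic ring for a saturated one on the carbonyl carbon does here. A modest step is therefore expected, most likely towards a higher number, estimated as a 3.6-fold higher number from compound 1 to compound 3 (0.56 log units; beyond the scatter). For compound 3 the expected value in this assay is 250 nM, within a range of 50 nM to 1500 nM.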

Compound 3, half-maximal inhibitory concentration: 2400 nM
For compound 3 the middle estimate is 9.6-fold (0.98 log units) below the measured one, and the stated range ends below it.
By their numbers in this assay, from the lowest: compound 1; then compound 3; then compound 2.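

With cyclohexyl in place of phenyl on the carbonyl carbon, this assay shows a 35-fold higher number from compound 1 to compound 3 (1.54 log units; beyond the scatter) and so reveals that this position, which the earlier pair left untouched, can also move the number a long way. The step is striking in that both groups hold the same count of heavy atoms, all carbon, and neither has hydrogen-bond donors or acceptors; the printed difference is that the ring is aromatic in compound 1 and non-aromatic in compound 3. Nothing available gives a reason for the size of this step.

As far as these compounds go, only these two rings appear on the carbonyl carbon, so it remains open how a phenyl carrying a methoxy group or an open chain such as butyl would behave there. Whether aromaticity itself is what matters at this position also stays unsettled.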